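The source may report more compounds than this note shows. Statements on the series, on what has been measured and on what is new or still open speak of the compounds shown alone.

In a functional assay on HCT-116 cells (Homo sapiens) for antiproliferative activity, read by sulforhodamine B assay (a lower number here means a stronger inhibitor, a higher number a weaker inhibitor), compound 1 `O=C1NC(=O)c2ccc(-n3cccc3)cc2/C1=C/Nc1ccc(CN2CCCCC2)cc1` gives 2700 nM, compound 2 `O=C1NC(=O)c2ccc(-c3ccsc3)cc2/C1=C/Nc1ccc(CN2CCCCC2)cc1` gives 1000 nM and compound 3 `O=C1NC(=O)c2ccc(-c3ccc(F)cc3)cc2/C1=C/Nc1ccc(CN2CCCCC2)cc1` gives 1000 nM. Compound 3 therefore stands level with compound 2, and together they hold the lowest of the three numbers. Compound 4 `O=C1NC(=O)c2ccc(-c3cccc(O)c3)cc2/C1=C/Nc1ccc(CN2CCCCC2)cc1` carries 3-hydroxyphenyl in place of 4-fluorophenyl on an aromatic carbon. Three measured steps change the group at this same place. Both a 2.7-fold lower number from compound 1 to compound 2 (0.43 log units; beyond the scatter) and a 2.7-fold lower number from compound 1 to compound 3 (0.43 log units; beyond the scatter) are modest, while no change at the digits printed from compound 2 to compound 3 (within the scatter) stays within the scatter. None of them brings in 3-hydroxyphenyl, so the expectation in this assay is no step beyond the scatter. The estimated step is a 1.1-fold lower number from compound 3 to compound 4 (0.05 log units; within the scatter). The expected value for compound 4 is 900 nM, with an estimated range of 350 nM to 2300 nM.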

Compound 4, half-maximal inhibitory concentration: 1300 nM
Beside the measured number, compound 4's estimate is 1.4-fold (0.16 log units) below it; measured number inside the range.
By their numbers in this assay, from the lowest: compounds 2, 3 and 4 (each within the scatter of the next); then compound 1.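

In this assay the change to 3-hydroxyphenyl gives a 1.3-fold higher number from compound 3 to compound 4 (0.11 log units; within the scatter) and a 1.3-fold higher number from compound 2 to compound 4 (0.11 log units; within the scatter) so a ring with a hydrogen-bond donor and acceptor, which 4-fluorophenyl lacks, fits this position without a step beyond the scatter. Against 1H-pyrrol-1-yl the same group gives a 2.1-fold lower number from compound 1 to compound 4 (0.32 log units; beyond the scatter) and so falls on the same side as thiophen-3-yl and 4-fluorophenyl. From the compounds shown here alone, whether an amine or a carboxylic acid on that phenyl ring would keep the number in this range stays open. No measured finding here explains these numbers.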